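One Methoxy Fewer: Expected Cytotoxicity of Compound 3

The compounds below may be only part of what the source reports. "The series", "measured", "known", "first", "only" and "open" are said of these compounds alone.

Compound 1, `COc1cc(-c2cc(/C=C/C(=O)c3ccc(N)cc3)[nH]n2)cc(OC)c1OC`: -24%
Compound 2, `COc1cc(-c2cc(/C=C/C(=O)c3ccc(Cl)c(Cl)c3)[nH]n2)cc(OC)c1OC`: 15%

In a functional assay on MCF7 cells (Homo sapiens) for cytotoxicity, read by sulforhodamine B assay, with a stated time of 48 h, tested at 10 uM (on this read-out lower numbers stand for a stronger effect and higher numbers for a weaker effect at the one concentration tested), compound 1 gives -24%, the lowest of the two numbers shown. Within the data shown here, the only measured step, a number 39 percentage points higher from compound 1 to compound 2 (beyond the scatter), came from a 3,4-dichlorophenyl in place of a 4-aminophenyl on a carbonyl carbon, so it concerns the other end of the shared core and does not bear on the change at hand. Compound 3, `COc1ccc(-c2cc(/C=C/C(=O)c3ccc(N)cc3)[nH]n2)cc1OC`, differs from compound 1 by hydrogen in place of methoxy on an aromatic carbon. Among the measured compounds shown here, with no measured step touching that position, compound 3 is expected to stay within the scatter of compound 1, a step of a number 12 percentage points higher from compound 1 to compound 3 (beyond the scatter). The value of compound 3 is therefore estimated at -12%, in the range -38% to 18%.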

Compound 3, a percentage reported as activity, at one concentration (the size of the read-out at that concentration, not a potency): -6%
The estimate for compound 3 lay 6 percentage points below the measured number; measured number inside the range.
By their numbers in this assay, from the lowest: compound 1; then compound 3; then compound 2.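

In this assay, hydrogen in place of methoxy on an aromatic carbon, ortho to a methoxy group and meta to a large group, gives a number 18 percentage points higher from compound 1 to compound 3 (beyond the scatter). This shows that the read-out responds to this position as well as to the group on the carbonyl carbon, with the loss of this one methoxy group producing a modest step. As far as these compounds go, whether a hydroxyl or an ethoxy group here would stay closer to compound 1 remains open, as does the effect of changing the two methoxy groups that remain in compound 3. No measurement shown gives a reason for this step.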